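Swapping Chloro for Methoxy on a Longer Side Chain

This account rests on a few compounds, and the source may have more. Where it says the series, first, only, none or still open, it means among the compounds named here.

Measured so far:
Compound 1, `CCCCCCC(CCO)n1cnc2c(Cl)ncnc21`: 16700 nM
Compound 2, `CCCCCCC(CCO)n1cnc2c(OC)ncnc21`: > 50000 nM
Compound 3, `CCCCCCCCCC(CCO)n1cnc2c(Cl)ncnc21`: 1150 nM

Of the compounds shown here, three with a shared core have been tested in a functional assay on SW480 cells (Homo sapiens) for antiproliferative activity, read by MTT assay, with a stated time of 48 h; on this read-out higher numbers stand for weaker inhibition and lower numbers for stronger inhibition. Compound 1 gives 16700 nM. Compound 2 reaches only a limit of the assay, > 50000 nM, which is the limit of > 50000 nM in this assay, at which 1 of the 3 values shown sits. Compound 3 gives 1150 nM in this assay.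

Two changes link these compounds. From compound 1 to compound 2 the change is methoxy in place of chloro on an aromatic carbon, and it brought an at least 2.9-fold higher number from compound 1 to compound 2 (0.47 log units; beyond the scatter). From compound 1 to compound 3 the core differs by propyl in place of hydrogen on a saturated chain carbon, seven bonds along the chain from an aromatic nitrogen, and that brought a 15-fold lower number from compound 1 to compound 3 (1.16 log units; beyond the scatter), making compound 3 the strongest of the two numbers in hand.

Compound 4, `CCCCCCCCCC(CCO)n1cnc2c(OC)ncnc21`, is not yet measured. It differs from compound 3 by methoxy in place of chloro on an aromatic carbon. Among the compounds with values here, this is the same change, at the same place, as the one from compound 1 to compound 2, now made on the core that carries the longer chain.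

The step from compound 3 to compound 4 in this assay is expected to be a 7.0-fold higher number from compound 3 to compound 4 (0.84 log units; beyond the scatter), a weakening of about the size seen before or larger, because the earlier step is known only as a lower bound since compound 2 sat at the limit of > 50000 nM in this assay, at which 1 of the 3 values shown sits. Compound 4 is therefore estimated at 8000 nM, most likely between 3000 nM and 30000 nM.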

Compound 4, half-maximal inhibitory concentration: 3250 nM
Compound 4: the middle estimate sits 2.5-fold (0.39 log units) above what was measured; the measured number falls inside the stated range.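

Methoxy in place of chloro gives a 2.8-fold higher number from compound 3 to compound 4 (0.45 log units; beyond the scatter) in this assay, which repeats the direction of the same change on the core of compound 1: the same change on two cores in this assay, an at least 2.9-fold higher number (0.47 log units; beyond the scatter) from compound 1 to compound 2 and a 2.8-fold higher number (0.45 log units; beyond the scatter) from compound 3 to compound 4; the limit leaves it open whether they differ

Read the other way, adding propyl to the chain on the methoxy core gives an at least 15-fold lower number from compound 2 to compound 4 (1.18 log units; beyond the scatter), and this matches the direction of the same change on the chloro core: the same change on two cores in this assay, a 15-fold lower number (1.16 log units; beyond the scatter) from compound 1 to compound 3 and an at least 15-fold lower number (1.18 log units; beyond the scatter) from compound 2 to compound 4; the limit leaves it open whether they differ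

Compound 2 gives > 50000 nM, which is a limit and not a number; these pairs show the direction of each change carrying from one core to the other, but they do not show that its size carries with it.

The compounds shown hold only chloro and methoxy on that aromatic carbon, leaving open how an amine or an ethoxy group there would read. They also leave open whether a longer chain would lower the number further, and whether the swap from chloro to methoxy would keep its direction on such a chain.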